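Sugar ring exchange on a benzoyl-protected nucleoside analogue

The source may report more compounds than this note shows. Statements on the series, on what has been measured and on what is new or still open speak of the compounds shown alone.

Measured so far:
compound 1 `C=C1C=CCO[C@@H]1n1cc(C)c(O)nc1=O` with >= 900000 nM in a functional assay on FM3A cells (Mus musculus), with a stated time of 2 days; a lower number here means a stronger inhibitor, a higher number a weaker inhibitor
compound 2 `O=C(Nc1ccn([C@H]2OCC=CC2=O)c(=O)n1)c1ccccc1` with 62000 nM

In this assay compound 1 gives only a limit, >= 900000 nM, and no number. Compound 2 gives 62000 nM, the only number shown, so it stands as the single measured value. Compound 3 `C=C1C=CCO[C@@H]1n1ccc(NC(=O)c2ccccc2)nc1=O` is not yet measured. It differs from compound 2 at one place: a group of 7 heavy atoms (6 carbon, 1 oxygen; one six-membered non-aromatic ring with 1 hetero atom) in place of a group of 7 heavy atoms (5 carbon, 2 oxygen; one six-membered non-aromatic ring with 1 hetero atom), on an aromatic nitrogen. The group that enters compound 3 is the same ring that compound 1 carries on its own core. Among the measured compounds shown here, no step between measured compounds is available, so the size of the change can only be expected. Because compound 1 sits at the limit (the limit of >= 900000 nM in this assay, at which 1 of the 2 values shown sits), compound 3 is expected to be weaker than compound 2, by a step of a 4.8-fold higher number from compound 2 to compound 3 (0.68 log units; beyond the scatter). Compound 3 is therefore estimated at 300000 nM, within a range from 60000 nM to 900000 nM, with a fair chance that only a limit is reported.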

Compound 3, half-maximal inhibitory concentration: 379000 nM
For compound 3 the middle estimate is 1.3-fold (0.10 log units) below the measured one, within the range that was stated.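

In this assay, the exchange on the aromatic nitrogen gives a 6.1-fold higher number from compound 2 to compound 3 (0.79 log units; beyond the scatter), so this position does respond to the ring it carries, and replacing the group of 5 carbon and 2 oxygen atoms with the group of 6 carbon and 1 oxygen atoms weakens inhibition. Compound 3 still gives a measured number, so on this core the entering ring does not take the reading to a limit. Compound 1, which carries the same ring on its own core, gives only a limit: the limit of >= 900000 nM in this assay, at which 1 of the 3 values shown sits.

The compounds shown leave open how the aromatic nitrogen would tolerate other groups, such as an open carbon chain in place of the ring, or a ring bearing a hydroxyl or an amine. A single step also cannot show whether this change would have a similar size on the core of compound 1.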